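A Hydroxy Group on the Anilino Ring: Expected Growth Inhibition

The source may hold more compounds than are shown below. What is called first, only, known or untested is meant among the compounds shown, and "the series" means these compounds.

Measured so far:
compound 1, `CC(C)CCn1cnc2c(Nc3ccccc3)nc(N[C@H]3CC[C@H](N)CC3)nc21`, 3500 nM
compound 2, `CCCCn1cnc2c(Nc3ccc(Cl)cc3)nc(N[C@H]3CC[C@H](N)CC3)nc21`, 2700 nM
compound 3, `CCCCn1cnc2c(Nc3ccccc3)nc(N[C@H]3CC[C@H](N)CC3)nc21`, 3200 nM

Of the compounds shown here, three sharing one core have been tested in a functional assay on K562 cells (Homo sapiens) for inhibition, read by fluorescence, with a stated time of 72 h; a higher number here means a weaker inhibitor of growth, a lower number a stronger inhibitor of growth. Compound 1 gives the highest of the three numbers, yet all three sit within the usual scatter of one another. Its nearest neighbour is compound 3, reached by a change on the chain: a 1.1-fold lower number from compound 1 to compound 3 (0.04 log units; within the scatter). Compound 2 and compound 3 differ on the aromatic ring, and that step, a 1.2-fold higher number from compound 2 to compound 3 (0.07 log units; within the scatter), is also within the scatter.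

Compound 4, `CC(C)CCn1cnc2c(Nc3ccc(O)cc3)nc(N[C@H]3CC[C@H](N)CC3)nc21`, is not yet measured. It differs from compound 1 by hydroxy in place of hydrogen on an aromatic carbon. The step from compound 2 to compound 3 bears most on it, since it swaps a substituent at the same kind of position, and it stayed within the scatter. Among the compounds with values here, no measured step involves a hydroxy group, so its specific effect is unknown. The expected step is a 1.2-fold lower number from compound 1 to compound 4 (0.07 log units; within the scatter), nothing beyond the scatter. Compound 4 is therefore estimated at 3000 nM, within 1200 nM to 8000 nM.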

Compound 4, concentration for 50% growth inhibition: 4600 nM
Estimate against measurement, compound 4: 1.5-fold (0.19 log units) below; low and high end bracket the measured number.
By their numbers in this assay, from the lowest: compounds 2, 3, 1 and 4 (each within the scatter of the next).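

Putting a hydroxy group on an aromatic carbon para to a large group, which turns phenyl into 4-hydroxyphenyl, gives in this assay a 1.3-fold higher number from compound 1 to compound 4 (0.12 log units; within the scatter), so compound 4 cannot be told apart from compound 1. The chloro step on the same kind of ring, a 1.2-fold higher number from compound 2 to compound 3 (0.07 log units; within the scatter), was also within the scatter, so on these two pairs neither hydroxy nor chloro separates from hydrogen at an aromatic carbon. No measurement shown here accounts for this result.

The compounds shown leave open whether an amine, a carboxylic acid or a methoxy group at this position would move the number beyond the scatter. They also leave open whether a hydroxy group on another carbon of this ring would do so.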